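The source may hold more compounds than are shown below. What is called first, only, known or untested is meant among the compounds shown, and "the series" means these compounds.

Measured so far in an ADME assay on Caco-2 cells (Homo sapiens) for permeability, in the apical to basolateral direction (a higher number here means that the compound crosses the layer faster, a lower number that the compound crosses the layer more slowly), as follows:
- compound 1 `COC(=O)N1CCN([C@H]2CC[C@H](Nc3ncnn4ccc([C@H](C)CC(=O)N(C)C)c34)CC2)CC1` gives 18 10^-6 cm/s
- compound 2 `CN(C)[C@H]1CC[C@H](Nc2ncnc3[nH]cc([C@H]4CC[C@H](C(N)=O)CC4)c23)CC1` gives < 0.2 10^-6 cm/s as a limit of the assay
- compound 3 `Cc1ccn2ncnc(N[C@H]3CC[C@H](N(C)C)CC3)c12` gives 36 10^-6 cm/s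

Among the compounds with values here, compound 3 (36 10^-6 cm/s) and compound 1 (18 10^-6 cm/s) lie within the scatter of each other, and these are the only two true numbers in the set. Compound 4 `CN(C)[C@H]1CC[C@H](Nc2ncnn3ccc([C@H]4CC[C@H](C(N)=O)CC4)c23)CC1` has 4-carbamoylcyclohexyl in place of methyl on an aromatic carbon of compound 3 4-carbamoylcyclohexyl in place of methyl on an aromatic carbon and is not yet measured. No measured step sizes this change. Compound 2 also carries 4-carbamoylcyclohexyl and its entry (< 0.2 10^-6 cm/s) is a limit of the assay, so a large fall in this assay is expected. The estimate amounts to a 36-fold lower number from compound 3 to compound 4 (1.56 log units; beyond the scatter) as an expected step. For compound 4 an estimated 1 10^-6 cm/s is expected, with 0.2 10^-6 cm/s to 5 10^-6 cm/s as the expected range.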

Compound 4, apparent permeability: < 0.8 10^-6 cm/s
Compound 4 gave a limit, no number (the forecaster's own chance of this, stated with the estimate: 25%); middle value at least 1.2-fold (0.09 log units) from the limit.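

In this assay 4-carbamoylcyclohexyl in place of methyl on an aromatic carbon gives an at least 45-fold lower number from compound 3 to compound 4 (1.65 log units; beyond the scatter) as the first step measured at this position. Compound 4 at < 0.8 10^-6 cm/s is a limit of the assay, not a number, so the step has a floor but no true size. Compound 4 joins compound 2, the other compound carrying this group, in returning only a limit.

Open, on these data alone, is whether the fall follows the carbamoyl group or the cyclohexyl ring. Plain cyclohexyl, or a short chain such as ethyl, at this aromatic carbon would separate the two.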